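The source may hold more compounds than are shown below. What is called first, only, known or untested is meant among the compounds shown, and "the series" means these compounds.

Compound 2 `Cc1cn(C/C=C\CNC(=O)c2ccccc2)c(=O)[nH]c1=O` was tested in a functional assay on MCF7 cells (Homo sapiens) for cytotoxicity, read by MTT assay, with a stated time of 72 h; on this read-out higher numbers stand for weaker inhibition and lower numbers for stronger inhibition. In this assay compound 2 gives only the limit of the assay, > 100000 nM, so no number is known for it. Compound 1 `O=C(NC/C=C\Cn1ccc(=O)[nH]c1=O)c1ccccc1` likewise gives only a limit in this assay, > 100000 nM. Among the measured compounds shown here, the one measured step, a step that the two limits leave unreadable from compound 1 to compound 2, cannot be read in size because of the limit of > 100000 nM in this assay, at which 2 of the 2 values shown sit. Compound 3 `O=C(NC/C=C\Cn1cc(C(F)(F)F)c(=O)[nH]c1=O)c1ccccc1` differs from compound 2 by trifluoromethyl in place of methyl on an aromatic carbon. For the measured compounds named here, no measured step bears directly on this change, and the only step available, a change from hydrogen to methyl at the same place, left no readable size. The expectation for compound 3 in this assay is therefore that it too sits at the limit, giving a step that the limit leaves unreadable from compound 2 to compound 3 that cannot be read. Compound 3 is estimated at 150000 nM, within a range from 30000 nM to 1000000 nM.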

Compound 3, half-maximal inhibitory concentration: > 100000 nM
Compound 3: no number, only a limit; the forecaster's own chance of this, stated with the estimate: 80%; the middle value lies beyond the limit too.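

Among the compounds shown here, compound 3 gives only a limit in this assay, as do compound 1 and compound 2, so no step among them can be read: the limit of > 100000 nM in this assay, at which 3 of the 3 values shown sit. The compounds shown leave open whether hydrogen, methyl and trifluoromethyl on this aromatic carbon differ at all in this assay, as none has a number.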